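The source may report more compounds than this note shows. Statements on the series, on what has been measured and on what is new or still open speak of the compounds shown alone.

Measured compounds in the series:

- compound 1, `COc1ccc2[nH]c([S+]([O-])Cc3ncc(C)c(N4CCCCC4)c3Cl)nc2c1`: 444 h
- compound 2, `COc1ccc2[nH]c([S+]([O-])Cc3ncc(C)c(N4CCCC4)c3Cl)nc2c1`: 60 h
- compound 3, `COc1ccc2[nH]c([S+]([O-])Cc3cc(N4CCCCC4)c(Br)cn3)nc2c1`: 864 h

In an ADME assay for pharmacokinetics, at pH 7.4 (a higher number here means that the compound lasts longer, a lower number that the compound disappears faster), compound 1 gives 444 h and compound 2 gives 60 h. The step of a 7.4-fold lower number from compound 1 to compound 2 (0.87 log units; beyond the scatter) goes with the change (pyrrolidin-1-yl in place of piperidin-1-yl on an aromatic carbon). Compound 3 gives 864 h in this assay. The difference between the core of compound 1 and the core of compound 3 is not broken down here; the two values lie within the usual scatter of each other, while the value of compound 2 sits clearly below both.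

Compound 4, `COc1ccc2[nH]c([S+]([O-])Cc3cc(N4CCCC4)c(Br)cn3)nc2c1`, has not yet been measured in this assay. It differs from compound 3 by pyrrolidin-1-yl in place of piperidin-1-yl on an aromatic carbon. Among the compounds with values here, this is the same kind of change as the one from compound 1 to compound 2, not the same change: the place in compound 1 is ortho to a chloro group and ortho to a methyl group, whereas in compound 3 the place is ortho to a bromo group, meta to a large group and opposite the ring nitrogen in both cases.

Within the data shown here, the step from compound 3 to compound 4 in this assay is expected to be of about the same size as the one seen before, a 7.2-fold lower number from compound 3 to compound 4 (0.86 log units; beyond the scatter), because the only measured instance of this kind of change, a 7.4-fold lower number from compound 1 to compound 2 (0.87 log units; beyond the scatter), is modest but beyond the scatter. With a single precedent on a different core, the spread is kept wide. Compound 4 is estimated at 120 h in this assay, expected between 40 h and 350 h.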

Compound 4, half-life: 49 h
Beside the measured number, compound 4's estimate is 2.4-fold (0.39 log units) above it; the measured number falls inside the stated range.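

In this assay, pyrrolidin-1-yl in place of piperidin-1-yl goes with an 18-fold lower number from compound 3 to compound 4 (1.25 log units; beyond the scatter) on the core of compound 3, so the direction seen on the core of compound 1 recurs, and the step is again beyond the scatter. Set side by side, the two steps cannot be told apart: the same change on two cores in this assay, a 7.4-fold lower number (0.87 log units; beyond the scatter) from compound 1 to compound 2 and an 18-fold lower number (1.25 log units; beyond the scatter) from compound 3 to compound 4, 2.4-fold (0.38 log units) apart, within the scatter of two such steps. The change therefore carries across these two cores as far as the data can resolve, but two cores are a narrow base: this says nothing about other cores, gives no reason for the shorter half-life with the smaller ring, and does not establish that the step is truly larger on the core of compound 3 than on the core of compound 1.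

Open is how other amines at this place would behave in this assay, for example morpholin-4-yl, piperazin-1-yl or an open-chain dimethylamino group, as the compounds shown carry only the piperidin-1-yl and pyrrolidin-1-yl rings. Also open is how the step would fare with a fluoro or nitrile group in place of the bromo group, and no pair shown separates the individual differences between the core of compound 1 and the core of compound 3.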